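Trifluoromethyl in place of chloro: what to expect

The source may hold more compounds than are shown below. What is called first, only, known or untested is meant among the compounds shown, and "the series" means these compounds.

Compound 2 `C#CCNC1CCc2c(SCCc3ccc(Cl)cc3)cccc21` is examined in an ADME assay on isolated protein for inhibition of Amine oxidase [flavin-containing] B (Homo sapiens) (on this read-out lower numbers stand for stronger inhibition and higher numbers for weaker inhibition), where compound 2 gives 920 nM. Among the numbers gathered so far this is the lowest of two: compound 1 `C#CCNC1CCc2c(SCCc3cccc(C)c3)cccc21` gives 4960 nM in this assay, and compound 3 `C#CCNC1CCc2c(SCCc3ccc(F)c(F)c3)cccc21` gives "not determined" (no result reported) in this assay, so no number is reported for it. Among the measured compounds shown here, the only step that can be read from these numbers, a 5.4-fold lower number from compound 1 to compound 2 (0.73 log units; beyond the scatter), is a modest one, and it concerns a different change, 4-chlorophenyl in place of 3-methylphenyl on a saturated chain carbon, two bonds along the chain from a sulfur. Compound 4 `C#CCNC1CCc2c(SCCc3ccc(C(F)(F)F)cc3)cccc21` differs from compound 2 only by trifluoromethyl in place of chloro on an aromatic carbon. For the measured compounds named here, no measured step bears directly on this exchange, since the single known step compares 4-chlorophenyl with 3-methylphenyl rather than a chloro with a trifluoromethyl. A step within the usual scatter is therefore expected, in either direction. For compound 4 the expected number in this assay is 1200 nM, within a range from 300 nM to 4500 nM. That estimate would mean a step of a 1.3-fold higher number from compound 2 to compound 4 (0.12 log units; within the scatter), expected to stay within the scatter.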

Compound 4, half-maximal inhibitory concentration: 8780 nM
The estimate for compound 4 lay 7.3-fold (0.86 log units) below the measured number, and the stated range ends below it.
By their numbers in this assay, from the lowest: compound 2; then compounds 1 and 4 (each within the scatter of the next).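

In this assay the exchange gives a 9.5-fold higher number from compound 2 to compound 4 (0.98 log units; beyond the scatter), so this position on an aromatic carbon does not treat chloro and trifluoromethyl as interchangeable, and the chloro of compound 2 is the better of the two here. Neither group carries a hydrogen-bond donor, a hydrogen-bond acceptor or a net charge, so these counts do not separate them, and the plain counted difference is 1 heavy atom leaving and 4 heavy atoms entering. Nothing measured here accounts for the size of this step.

Compound 3 has no number, so steps to it cannot be read. As far as these compounds go, it remains open how a bromo, a methoxy or a nitrile at this same position would compare with chloro and trifluoromethyl.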